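A few compounds are considered here, and "the series" means these few. Any claim that something is new, unique, unknown or untested is made for them only; others in the source may bear on it.

Series notes. Three measured compounds share one core and differ only in the saturated ring attached through a chain carbon to the sulfonamide nitrogen. In a physicochemical assay for lipophilicity, read by HPLC, measured as octanol-water partition, at pH 7.4 (on this read-out higher numbers stand for higher lipophilicity and lower numbers for lower lipophilicity), compound 1 `CC1(C)C[C@H](CN([C@H](CCC(F)(F)F)C(N)=O)S(=O)(=O)c2ccc(Cl)cc2)O1` gives 3.8. In this assay compound 2 `NC(=O)[C@@H](CCC(F)(F)F)N(C[C@H]1CCCOC1)S(=O)(=O)c1ccc(Cl)cc1` gives 3.6. In this assay compound 3 `NC(=O)[C@@H](CCC(F)(F)F)N(C[C@@H]1CCCOC1)S(=O)(=O)c1ccc(Cl)cc1` gives 3.7. Compound 3 sits among the three numbers, within the scatter of each neighbour: a number 0.10 log units lower from compound 1 to compound 3 (within the scatter), and a number 0.10 log units higher from compound 2 to compound 3 (within the scatter). Compounds 2 and 3 are the same molecule in a different drawn configuration (the fact that compounds 2 and 3 differ only in the configuration as drawn), and neither that pair nor the step of a number 0.20 log units lower from compound 1 to compound 2 (within the scatter) moves beyond the scatter.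

Compound 4 `NC(=O)[C@@H](CCC(F)(F)F)N(C[C@@H]1COCCO1)S(=O)(=O)c1ccc(Cl)cc1` carries the change (1,4-dioxan-2-yl in place of oxan-3-yl on a saturated chain carbon bound to a sulfonamide nitrogen). The measured steps swap one saturated ring for another or invert a ring stereocentre, and all three lie within the scatter; none exchanges a ring carbon for a second ring oxygen, so they do not cover this change directly. The estimate is therefore placed somewhat lower than compound 3, with a wide range, as an expected step of a number 0.60 log units lower from compound 3 to compound 4 (beyond the scatter) in this assay. Compound 4 is expected to read 3.1, between 2.6 and 3.6.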

Compound 4, distribution coefficient: 2.75
The estimate for compound 4 lay 0.35 log units above the measured number; measured number inside the range.
By their numbers in this assay, from the lowest: compound 4; then compounds 2, 3 and 1 (each within the scatter of the next).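

In this assay, for the compounds shown here, the change to 1,4-dioxan-2-yl at this place, on a saturated chain carbon bound to a sulfonamide nitrogen, gives the first steps that lie beyond the scatter: a number 0.95 log units lower from compound 3 to compound 4 (beyond the scatter), and a number 0.85 log units lower from compound 2 to compound 4 (beyond the scatter). Both steps start from oxan-3-yl, so the result holds for either drawn configuration of that ring, and the two compounds give two separate reference points for one change: the fact that compounds 2 and 3 differ only in the configuration as drawn. Against 4,4-dimethyloxetan-2-yl the step is a number 1.05 log units lower from compound 1 to compound 4 (beyond the scatter), so a swap of saturated ring that stayed within the scatter for compound 2 and compound 3 goes beyond it once the six-membered ring holds 2 hetero atoms rather than 1.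

From the compounds shown here alone, all of this rests on compound 4 alone, so it stays open whether the step follows the second ring oxygen as such or its location in the ring, and how the opposite configuration of 1,4-dioxan-2-yl would read. Going by these compounds, it is also open how the same read-out would respond to an amine nitrogen in place of that second ring oxygen.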